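This account rests on a few compounds, and the source may have more. Where it says the series, first, only, none or still open, it means among the compounds named here.

Three compounds of this series have been measured in an ADME assay for permeability, using PAMPA, with a stated time of 30 min, at pH 7.4; on this read-out higher numbers stand for higher permeability and lower numbers for lower permeability:

- compound 1 `COc1ccc(Oc2ccc3c(NCCCNCc4cccc(OC)c4O)ccnc3c2)cc1`, giving 317 10^-6 cm/s
- compound 2 `c1ccc(-c2ccc3c(NCCCNCc4ccco4)ccnc3c2)cc1`, giving 237 10^-6 cm/s
- compound 3 `COc1cccc(CNCCCNc2ccnc3cc(-c4ccccc4)ccc23)c1O`, giving 237 10^-6 cm/s

Compound 3 and compound 2 share one core and differ at the chain end, where compound 2 carries furan-2-yl in place of 2-hydroxy-3-methoxyphenyl on a saturated chain carbon bound to an amine nitrogen; in this assay this reads as no change at the digits printed from compound 2 to compound 3 (within the scatter). Compound 3 and compound 1 differ on the aromatic carbon of the shared core, with 4-methoxyphenoxy in place of phenyl on an aromatic carbon; the step there is a 1.3-fold higher number from compound 3 to compound 1 (0.13 log units; within the scatter).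

Compound 4 `COc1ccc(Oc2ccc3c(NCCCNCc4ccco4)ccnc3c2)cc1` has not yet been measured in this assay. It stands to compound 2 as compound 1 stands to compound 3: the difference is 4-methoxyphenoxy in place of phenyl on an aromatic carbon, at a place described in the same words as for the pair of compound 3 and compound 1, so the two changes are the same change. As the measured step was a 1.3-fold higher number from compound 3 to compound 1 (0.13 log units; within the scatter), the step from compound 2 is expected to be a 1.3-fold higher number from compound 2 to compound 4 (0.10 log units; within the scatter), resting on that single measured pair. Compound 4 is therefore estimated at 300 10^-6 cm/s in this assay, with the expected range running from 200 10^-6 cm/s to 450 10^-6 cm/s.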

Compound 4, apparent permeability: 317 10^-6 cm/s
Compound 4: middle estimate off by 1.1-fold (0.02 log units), on the low side, within the range that was stated.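

In this assay, 4-methoxyphenoxy in place of phenyl gives a 1.3-fold higher number from compound 2 to compound 4 (0.13 log units; within the scatter), which agrees with the same change on the other core: the same change on two cores in this assay, a 1.3-fold higher number (0.13 log units; within the scatter) from compound 3 to compound 1 and a 1.3-fold higher number (0.13 log units; within the scatter) from compound 2 to compound 4, 1.0-fold (0.00 log units) apart, within the scatter of two such steps. Furan-2-yl in place of 2-hydroxy-3-methoxyphenyl gives no change at the digits printed from compound 1 to compound 4 (within the scatter), and this too agrees with the earlier pair: the same change on two cores in this assay, no change at the digits printed (within the scatter) from compound 2 to compound 3 and no change at the digits printed (within the scatter) from compound 4 to compound 1, 1.0-fold (0.00 log units) apart, within the scatter of two such steps. These matching pairs show that, on these cores, neither change produces a step beyond the scatter on either core, but they do not show that either change truly alters the read-out, and they rest on only four compounds, so they establish no rule for the wider series.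

The compounds shown leave open whether the same agreement would hold for other groups, such as a chlorine atom or a morpholine in place of phenyl, or a carboxylic acid or a longer chain at the chain end. They also leave open whether a step beyond the scatter would carry from one core to another as closely, as every step here lies within it.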